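Cyclopentyl to cyclobutylmethyl on the compound 1 series

The source may hold more compounds than are shown below. What is called first, only, known or untested is meant among the compounds shown, and "the series" means these compounds.

Measured in a physicochemical assay for solubility; a lower number here means a less soluble compound, a higher number a more soluble compound:
- compound 1 `CNc1nc(OC2CCCC2)nc2c1ncn2Cc1c(F)cccc1F`: 9000 nM
- compound 2 `CNC(=O)c1sc(N2CC3CC2(CNC(=O)c2c[nH]c4ncc(C(F)(F)F)cc24)C3)nc1C(F)(F)F`: < 1600 nM (a limit)

For the measured compounds named here, compound 1 holds the only actual number in this assay, at 9000 nM. Compound 2 gives < 1600 nM, which is a limit of the assay and not a number.

Compound 3 `CNc1nc(OCC2CCC2)nc2c1ncn2Cc1c(F)cccc1F` keeps the core of compound 1 and carries cyclobutylmethyl in place of cyclopentyl on an oxygen on an aromatic ring. The two have the same atoms, joined differently. Going by the values given here, no measured pair here shows this change, so the expectation starts from compound 1 at 9000 nM. The expected size is none beyond the scatter, with no direction favoured: no change at the digits printed from compound 1 to compound 3 (within the scatter). For compound 3 the estimated value is 9000 nM, with an expected range of 4000 nM to 20000 nM.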

Compound 3, solubility: 4000 nM
Compound 3: middle estimate off by 2.3-fold (0.35 log units), on the high side; the range from low to high includes it.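

In this assay, replacing cyclopentyl with cyclobutylmethyl on an oxygen on an aromatic ring gives a 2.3-fold lower number from compound 1 to compound 3 (0.35 log units; beyond the scatter). The two compounds have the same atoms, joined differently, so rearranging the group at this position is enough to move the reading beyond the scatter, although the step is modest. Nothing available bears on the cause of this step.

As far as these compounds go, this is a single step on one core, so it remains open whether the same change would give a similar step on another core. Also open, from the compounds shown here alone, is how this assay would respond at this oxygen to a group carrying an amine or a carboxylic acid, or to a longer chain, and in which direction the reading would move.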